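This account rests on a few compounds, and the source may have more. Where it says the series, first, only, none or still open, it means among the compounds named here.

Of the compounds shown here, three sharing one core have been measured in a functional assay on SW-620 cells (Homo sapiens) for inhibition, read by MTT assay, with a stated time of 72 h; a lower number here means a stronger inhibitor, a higher number a weaker inhibitor. Compound 1 `COc1cc(Oc2cccc(Nc3ccccc3)c2)cc(OC)c1CNCc1ccc(F)cc1` gives 6770 nM in this assay. Compound 2 `CNCc1c(OC)cc(Oc2cccc(Nc3ccccc3)c2)cc1OC`, in which hydrogen replaces the 4-fluorophenyl on a saturated chain carbon bound to an amine nitrogen, gives 15000 nM in this assay. Compound 3 `COc1cc(Oc2cccc(Nc3ccccc3)c2)cc(OC)c1CNCCNC(C)=O` gives 11900 nM in this assay, which is the second highest of the three numbers; its nearest neighbour is compound 2 and its furthest is compound 1, and both of those gaps lie within the usual scatter of repeated measurements.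

Compound 4 `COc1cc(Oc2cccc(Nc3ccccc3)c2)cc(OC)c1CNCc1ccc(C)cc1` is not yet measured. Compared with compound 3, the change is 4-methylphenyl in place of acetamidomethyl on a saturated chain carbon bound to an amine nitrogen. The measured step that bears most directly on this change is a 1.8-fold higher number from compound 1 to compound 3 (0.24 log units; within the scatter), since compound 4 largely undoes that change, putting an aromatic ring back in place of the chain. A second step, a 1.3-fold lower number from compound 2 to compound 3 (0.10 log units; within the scatter), also stayed within the scatter, so the chain itself has not moved the number much in either direction. The number for compound 4 is therefore expected to come down somewhat, roughly to where compound 1 stands, with a 1.7-fold lower number from compound 3 to compound 4 (0.23 log units; within the scatter). Compound 4 is estimated at 7000 nM in this assay, with a range from 3000 nM to 16000 nM.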

Compound 4, half-maximal inhibitory concentration: 11800 nM
Beside the measured number, compound 4's estimate is 1.7-fold (0.23 log units) below it; measured number inside the range.
By their numbers in this assay, from the lowest: compounds 1, 4, 3 and 2 (each within the scatter of the next, the first and the last beyond it).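

In this assay, putting 4-methylphenyl in place of acetamidomethyl gives a 1.0-fold lower number from compound 3 to compound 4 (0.00 log units; within the scatter) and so leaves the reading where it was, even though an aromatic ring of carbon only replaces a group with an amide. Set against a hydrogen at this saturated chain carbon bound to an amine nitrogen, the same ring gives a 1.3-fold lower number from compound 2 to compound 4 (0.10 log units; within the scatter) and this also stays within the scatter, whereas the step with 4-fluorophenyl, a 2.2-fold higher number from compound 1 to compound 2 (0.35 log units; beyond the scatter) and just beyond the scatter, does not. Within the data shown here, the first change on the ring itself, methyl in place of fluoro, gives a 1.7-fold higher number from compound 1 to compound 4 (0.24 log units; within the scatter) and cannot be told from scatter, so the one step beyond the scatter rests on a narrow margin and does not show that an aromatic ring in general matters here.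

Still open, going by these compounds, is how a carboxylic acid, a morpholine ring or a longer chain would read at this place, and whether any group there can move the number well beyond the scatter. The data shown offer no measurement that explains any of these readings.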